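The source may hold more compounds than are shown below. What is called first, only, known or untested is meant among the compounds shown, and "the series" means these compounds.

Measured so far:
compound 1 `COc1ccc2[nH]c(S(=O)(=O)Cc3ccc(OCc4nccc(OC)c4OC)c(OC)c3)nc2c1` gives 898 nM
compound 2 `COCCCOc1ccnc(COc2ccc(CS(=O)(=O)c3nc4cc(OC(F)F)ccc4[nH]3)cc2OC)c1C` gives 142 nM

In a functional assay on cells (Erythrocyte, Homo sapiens) (a lower number here means a stronger inhibitor, a higher number a weaker inhibitor), compound 1 gives 898 nM. Compound 2 gives 142 nM, the lowest of the two numbers; compound 1 is the nearest and stands at a higher number, a gap beyond the scatter. Among the compounds with values here, no pair of measured compounds differs in one place only, so the size of a single change is not known from these two.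

Compound 3 `COCCCOc1ccnc(COc2ccc(CS(=O)(=O)c3nc4cc(OC)ccc4[nH]3)cc2OC)c1C` is not yet measured. It differs from compound 2 in one place: methyl in place of difluoromethyl on an oxygen on an aromatic ring. Compound 1 also carries a methoxy at that oxygen. Compound 1 differs from compound 2 in several other places as well, so the gap between compound 1 and compound 2 does not show what this change alone does.

For this assay the expected step from compound 2 to compound 3 is a 1.5-fold higher number from compound 2 to compound 3 (0.19 log units; within the scatter), a small move toward weaker inhibition, not beyond the scatter. Compound 3 is therefore estimated at 220 nM, within 70 nM to 700 nM.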

Compound 3, half-maximal inhibitory concentration: 817 nM
Beside the measured number, compound 3's estimate is 3.7-fold (0.57 log units) below it; measured number outside the range, above it.
By their numbers in this assay, from the lowest: compound 2; then compounds 3 and 1 (each within the scatter of the next).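

In this assay, within the data shown here, difluoromethoxy to methoxy on the aromatic ring gives the first step that can be read on its own: a 5.8-fold higher number from compound 2 to compound 3 (0.76 log units; beyond the scatter). This single change, with the rest of the structure held constant, moves the number toward weaker inhibition by more than the scatter, so this position matters, and difluoromethyl on the oxygen is the better of the two groups compared here. No measurement in hand gives a reason for this step.

As far as these compounds go, with only these two groups read at this oxygen, it remains open how trifluoromethyl, ethyl or a longer alkyl chain there would compare. The compounds shown also leave open whether the same step would hold on the core of compound 1, which carries a methoxy at this oxygen but differs in several other places.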